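Amide variation on the shared dihydroxy acid series

A few compounds are considered here, and "the series" means these few. Any claim that something is new, unique, unknown or untested is made for them only; others in the source may bear on it.

Compound 1 `CC(C)c1c(C(=O)N2CCCCC2)nn(-c2ccc(F)cc2)c1OC[C@@H](O)C[C@@H](O)CC(=O)O` gives 32200 nM in a functional assay on L6 cells (Rattus norvegicus) for inhibition; on this read-out higher numbers stand for weaker inhibition and lower numbers for stronger inhibition. Compound 2 `COc1ccc(CNC(=O)c2nn(-c3ccc(F)cc3)c(OC[C@@H](O)C[C@@H](O)CC(=O)O)c2C(C)C)cc1` carries a different amide on the same core and stands at "not determined" (no result reported) in this assay, so it offers no anchor of its own. Compound 3 `CC(C)c1c(C(=O)N(C)Cc2cccc(F)c2)nn(-c2ccc(F)cc2)c1OC[C@@H](O)C[C@@H](O)CC(=O)O` differs from compound 2 by the change ((3-fluorobenzyl)(methyl)amino in place of (4-methoxybenzyl)amino on a carbonyl carbon). Within the data shown here, no measured step of this kind is available, so the direction of the effect in this assay is unknown, and the only footing is compound 1 at 32200 nM. Compound 3 is expected near 25000 nM, with a range from 5000 nM to 100000 nM.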

Compound 3, half-maximal inhibitory concentration: 2470 nM
Beside the measured number, compound 3's estimate is 10-fold (1.01 log units) above it; measured number below the stated range.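

In this assay, the amide group on the carbonyl carbon proves able to move the read-out: (3-fluorobenzyl)(methyl)amino in place of piperidin-1-yl gives a 13-fold lower number from compound 1 to compound 3 (1.12 log units; beyond the scatter), a step towards stronger inhibition. Among these compounds, this is the only readable step so far. Nothing at hand accounts for its size.

Compound 2 has no number, so its step to compound 3 cannot be read, and the shares of the fluorine and the methyl stay unsplit. On these data alone, how a benzyl(methyl)amino or morpholin-4-yl amide would stand remains open.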